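The source may hold more compounds than are shown below. What is called first, only, known or untested is meant among the compounds shown, and "the series" means these compounds.

Compounds measured in an assay on HEK293 cells for displacement of a labelled ligand from Melanocortin receptor 4 (Homo sapiens); a higher number here means a weaker inhibitor, a lower number a stronger inhibitor:
compound 1 `Cc1cc(CC(C)C(=O)N2CCN(c3ccc(C(F)(F)F)cc3[C@@H](N)CC(C)C)CC2)ccc1Cl` gives 71 nM;
compound 2 `CCOc1cccc(CC(C)C(=O)N2CCN(c3ccc(C(F)(F)F)cc3[C@@H](N)CC(C)C)CC2)c1` gives 2200 nM.

Compound 2 stands with the highest number of the two, its nearest neighbour being compound 1. Compound 3 `Cc1ccc(CC(C)C(=O)N2CCN(c3ccc(C(F)(F)F)cc3[C@@H](N)CC(C)C)CC2)cc1C` differs from compound 2 by 3,4-dimethylphenyl in place of 3-ethoxyphenyl on a saturated chain carbon, two bonds along the chain from a carbonyl carbon. For the measured compounds named here, the only step that bears on this change is a 31-fold higher number from compound 1 to compound 2 (1.49 log units; beyond the scatter), which was large. Since compound 3 carries a 3,4-dimethylphenyl rather than the 3-ethoxyphenyl of compound 2, the step is expected to run back toward the number of compound 1, so compound 3 is expected at 150 nM (range 40 nM to 600 nM), a step of a 15-fold lower number from compound 2 to compound 3 (1.17 log units; beyond the scatter).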

Compound 3, inhibition constant: 240 nM
The estimate for compound 3 lay 1.6-fold (0.20 log units) below the measured number, and the stated range covers the measured number.
By their numbers in this assay, from the lowest: compound 1; then compound 3; then compound 2.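

In this assay, 3,4-dimethylphenyl in place of 3-ethoxyphenyl brings the number most of the way back (a 9.2-fold lower number from compound 2 to compound 3 (0.96 log units; beyond the scatter)), so the high number of compound 2 does not extend to every substituted phenyl at this position. Methyl in place of chloro on an aromatic carbon still counts (a 3.4-fold higher number from compound 1 to compound 3 (0.53 log units; beyond the scatter)), leaving compound 1 lowest of the three. Nothing available gives a reason for either step. From the compounds shown here alone, it remains open whether a methoxy group in place of the ethoxy would give a number like compound 2, and how bromo or trifluoromethyl in place of the chloro would read.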